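From Compound 3 to Compound 4: Hydroxy to Methoxy

A few compounds are considered here, and "the series" means these few. Any claim that something is new, unique, unknown or untested is made for them only; others in the source may bear on it.

Of the compounds shown here, three have been measured in a functional assay on NCI-H460 cells (Homo sapiens) for inhibition, read by sulforhodamine B assay, with a stated time of 48 h, tested at 10 uM; on this read-out lower numbers stand for a stronger effect and higher numbers for a weaker effect at the one concentration tested. Compound 1 `COc1cc(Cl)cc(-c2nn(-c3cccc(NC(=O)Nc4cccc(C(F)(F)F)c4)c3)cc2-c2ccncc2)c1` gives -6.11%, compound 2 `COc1cc(Cl)cc(-c2nn(-c3cccc(NC(=O)c4cccc(C(F)(F)F)c4)c3)cc2-c2ccncc2)c1` gives 41.1%, and compound 3 `O=C(Nc1cccc(-n2cc(-c3ccncc3)c(-c3cc(O)cc(Cl)c3)n2)c1)c1cc(C(F)(F)F)cc(C(F)(F)F)c1` gives 19.9%. Compound 3 thus stands second highest of the three, nearer to compound 2 than to compound 1. Among the measured compounds shown here, the only single-point step among them, a number 47.2 percentage points higher from compound 1 to compound 2 (beyond the scatter), concerns the group on the carbonyl carbon and not the change now in question. Compound 4 `COc1cc(Cl)cc(-c2nn(-c3cccc(NC(=O)c4cc(C(F)(F)F)cc(C(F)(F)F)c4)c3)cc2-c2ccncc2)c1` differs from compound 3 by methyl in place of hydrogen on an oxygen on an aromatic ring, hydroxy becoming methoxy. For the measured compounds named here, no measured step bears on this change, so the step in this assay is expected to be small or none beyond the scatter. Compound 4 is estimated at 25%, within 0% to 50%, an expected step of a number 5.1 percentage points higher from compound 3 to compound 4 (within the scatter).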

Compound 4, a percentage reported as activity, at one concentration (the size of the read-out at that concentration, not a potency): 41%
Estimate against measurement, compound 4: 16 percentage points below; the range from low to high includes it.
By their numbers in this assay, from the lowest: compound 1; then compound 3; then compounds 4 and 2 (each within the scatter of the next).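

In this assay, the change from hydroxy to methoxy on the 3-chloro-5-hydroxyphenyl group weakens the effect, with a number 21.1 percentage points higher from compound 3 to compound 4 (beyond the scatter), so this oxygen is not indifferent to methyl in place of hydrogen. With methoxy in place, the added trifluoromethyl on an aromatic carbon gives a number 0.1 percentage points lower from compound 2 to compound 4 (within the scatter), so this second substituent does not alter the read-out. No measured evidence accounts for the hydroxy to methoxy step.

On these data alone, how an amine or an ethoxy group would read at this position remains open. So does whether the hydroxy to methoxy step would hold with the urea linker of compound 1.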